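The compounds below may be only part of what the source reports. "The series", "measured", "known", "first", "only" and "open" are said of these compounds alone.

Measured so far:
compound 1 `N#Cc1ccc(-c2nc(NCCNc3ccc([N+](=O)[O-])c(N)n3)ncc2-c2ncc[nH]2)cc1`, only a limit of the assay: > 0.5 h
compound 2 `Nc1nc(NCCNc2ncc(-c3ncc[nH]3)c(-c3ccc(F)cc3Br)n2)ccc1[N+](=O)[O-]`, only a limit of the assay: > 0.5 h

In an ADME assay on microsomes from liver (Canis lupus familiaris) for metabolic stability (on this read-out higher numbers stand for a longer-lived compound and lower numbers for a shorter-lived compound), compound 1 gives a limit rather than a number, > 0.5 h. In this assay compound 2 also gives a limit, > 0.5 h. The step that the two limits leave unreadable from compound 1 to compound 2 is therefore unreadable, as both values sit at the limit of > 0.5 h in this assay, at which 2 of the 2 values shown sit. Compound 3 `Cc1cc(Cl)ccc1-c1nc(NCCNc2ccc([N+](=O)[O-])c(N)n2)ncc1-c1ncc[nH]1` differs from compound 2 by 4-chloro-2-methylphenyl in place of 2-bromo-4-fluorophenyl on an aromatic carbon. Within the data shown here, the only measured step has no readable size, so no shift beyond the scatter is expected. Compound 3 is estimated at 1 h, between 0.5 h and 3 h. This estimate means an expected step that the limit leaves unreadable from compound 2 to compound 3.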

Compound 3, half-life: > 0.5 h
Compound 3 gave a limit, no number; the forecaster's own chance of this, stated with the estimate: 75%; the middle value lies beyond the limit too.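

Compound 1, compound 2 and compound 3 all give only a limit in this assay, so no step between them can be read: the limit of > 0.5 h in this assay, at which 3 of the 3 values shown sit.

On these data alone, what stays open is each compound's actual half-life, and whether exchanging 4-cyanophenyl, 2-bromo-4-fluorophenyl and 4-chloro-2-methylphenyl changes it at all.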